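The compounds below may be only part of what the source reports. "The series", "measured", "known", "first", "only" and "open" are said of these compounds alone.

Series notes. Among the compounds with values here, compound 3 `Nc1cccc(C2=NC(c3ccc(F)cc3)(c3ccc(F)cc3)CN2)c1` gives 300 nM in an assay on LM cells for displacement of a labelled ligand from Neuropeptide Y receptor type 5 (Homo sapiens) (a higher number here means a weaker inhibitor, a lower number a stronger inhibitor), the highest number of the three measured so far. Compound 1 `Fc1ccc(C2(c3ccc(F)cc3)CNC(c3ccccc3)=N2)cc1` gives 32 nM in this assay, and compound 2 `N#Cc1cccc(C2=NC(c3ccc(F)cc3)(c3ccc(F)cc3)CN2)c1` gives 2.7 nM. The measured steps are a 12-fold lower number from compound 1 to compound 2 (1.07 log units; beyond the scatter), a 9.4-fold higher number from compound 1 to compound 3 (0.97 log units; beyond the scatter) and a 110-fold higher number from compound 2 to compound 3 (2.05 log units; beyond the scatter).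

Compound 4 `Fc1ccc(C2(c3ccc(F)cc3)CNC(c3cccnc3)=N2)cc1` differs from compound 3 by pyridin-3-yl in place of 3-aminophenyl on a carbon with a double bond to nitrogen. Within the data shown here, no measured step covers a ring nitrogen at this place. The step that bears most directly is the loss of the amino group, the reverse of a 9.4-fold higher number from compound 1 to compound 3 (0.97 log units; beyond the scatter), which on its own would bring compound 4 close to compound 1. Compound 2 also carries an acceptor, and there a 12-fold lower number from compound 1 to compound 2 (1.07 log units; beyond the scatter) was seen, but whether a ring nitrogen counts the same way is not shown, so only part of such a gain is assumed. Compound 4 is therefore expected at 20 nM, with a range of 5 nM to 80 nM. The expected step is a 15-fold lower number from compound 3 to compound 4 (1.18 log units; beyond the scatter), toward a lower number in this assay.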

Compound 4, half-maximal inhibitory concentration: 7.2 nM
For compound 4 the middle estimate is 2.8-fold (0.44 log units) above the measured one; low and high end bracket the measured number.
By their numbers in this assay, from the lowest: compound 2; then compound 4; then compound 1; then compound 3.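

In this assay, pyridin-3-yl in place of phenyl on the carbon with a double bond to nitrogen gives a 4.4-fold lower number from compound 1 to compound 4 (0.65 log units; beyond the scatter), so a lower number at this place does not require a nitrile substituent on a phenyl ring. Pyridin-3-yl still falls short of 3-cyanophenyl, with a 2.7-fold higher number from compound 2 to compound 4 (0.43 log units; beyond the scatter), while its advantage over 3-aminophenyl is much larger, at a 42-fold lower number from compound 3 to compound 4 (1.62 log units; beyond the scatter); the order at this place across the four compounds is 3-cyanophenyl, pyridin-3-yl, phenyl, 3-aminophenyl. No measurement on these compounds accounts for that order. From the compounds shown here alone, whether the location of the ring nitrogen matters remains open, as pyridin-2-yl and pyridin-4-yl would test. Also open, going by these compounds, is how a methoxy or carboxylic acid group on the phenyl ring would compare with the nitrile and the amine.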